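This account rests on a few compounds, and the source may have more. Where it says the series, first, only, none or still open, it means among the compounds named here.

Measured so far in a functional assay on the whole organism (stomach) with Rattus norvegicus as the target; a higher number here means that more compound is needed for the effect, a lower number that less compound is needed:
compound 1, `N=C(S)CCCCCn1nc(-c2ccccc2)ccc1=O`, giving 23.3 mg/kg
compound 2, `N=C(S)CCn1nc(-c2ccccc2)ccc1=O`, giving 87.3 mg/kg
compound 3, `N=C(S)CCN1N=C(c2ccccc2)CCC1=O`, where only a limit is reached

For compound 3 the read-out is a limit and not a number, > 100 mg/kg, which is the limit of > 100 mg/kg in this assay, at which 1 of the 3 values shown sits.

Within the core of compound 2, the one step of the series is a 3.7-fold lower number from compound 2 to compound 1 (0.57 log units; beyond the scatter), the change being (a group of 6 heavy atoms (4 carbon, 1 nitrogen, 1 sulfur; no ring) in place of a group of 3 heavy atoms (1 carbon, 1 nitrogen, 1 sulfur; no ring), on a saturated chain carbon, two bonds along the chain from an aromatic nitrogen). The difference between the core of compound 2 and the core of compound 3 is not broken down here; compound 2 gives a number while compound 3 stays at the limit.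

Compound 4, `N=C(S)CCCCCN1N=C(c2ccccc2)CCC1=O`, is not yet measured. It stands to compound 3 as compound 1 stands to compound 2: a group of 6 heavy atoms (4 carbon, 1 nitrogen, 1 sulfur; no ring) in place of a group of 3 heavy atoms (1 carbon, 1 nitrogen, 1 sulfur; no ring), on a saturated chain carbon, two bonds along the chain from an amide-type nitrogen in a ring. This is the same kind of change, though not the same, since here the group sits two bonds along the chain from an amide-type nitrogen in a ring rather than two bonds from an aromatic nitrogen.

Because a 3.7-fold lower number from compound 2 to compound 1 (0.57 log units; beyond the scatter) ran in favour of the longer chain, a step of about an at least 1.4-fold lower number from compound 3 to compound 4 (0.15 log units; that floor lies within the scatter) is expected from compound 3 to compound 4 in this assay. The value expected for compound 4 is 70 mg/kg, most likely between 25 mg/kg and 200 mg/kg, with a fair chance that only a limit is again reported.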

Compound 4, dose for half-maximal effect: 100 mg/kg
For compound 4 the middle estimate is 1.4-fold (0.15 log units) below the measured one, within the range that was stated.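

In this assay, the longer chain on the core of compound 3 gives a number no higher from compound 3 to compound 4 (the limit leaves the size open), so this core shows nothing that runs against the direction seen on the core of compound 2. The read-out of compound 3 is a limit and not a number: the limit of > 100 mg/kg in this assay, at which 1 of the 4 values shown sits. Set beside the earlier step, the result supports at most a shared direction and does not show that the size of the step carries from one core to the other: the same change on two cores in this assay, a 3.7-fold lower number (0.57 log units; beyond the scatter) from compound 2 to compound 1 and a number no higher (the limit leaves the size open) from compound 3 to compound 4; the limit leaves it open whether they differ

The compounds shown cover only the two groups compared here on each core, so they leave open how a longer chain would read in this assay on either core. Also open, from the compounds shown here alone, is whether an amine or a carboxylic acid in place of these groups would keep the effect on the core of compound 2 or the core of compound 3.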